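A Dichlorophenyl Swap on a Shared Core

The compounds below may be only part of what the source reports. "The series", "measured", "known", "first", "only" and "open" are said of these compounds alone.

Compound 1, `CCOc1ccc(-c2ccc3ncn(-c4cc(OC)c(OC)c(OC)c4)c3c2)cc1`: 8550 nM
Compound 2, `COc1cc(-n2cnc3ccc(-c4cccc(C)c4)cc32)cc(OC)c1OC`: 3820 nM

Among the compounds with values here, in a functional assay on A549 cells (Homo sapiens) for antiproliferative activity, read by MTT assay, with a stated time of 72 h (a lower number here means a stronger inhibitor, a higher number a weaker inhibitor), compound 2 gives 3820 nM, the lowest of the two numbers measured so far, and compound 1 gives 8550 nM. Within the data shown here, the one measured step, a 2.2-fold lower number from compound 1 to compound 2 (0.35 log units; beyond the scatter), came from exchanging the aryl group attached to the shared core.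

Compound 3, `COc1cc(-n2cnc3ccc(-c4ccc(Cl)cc4Cl)cc32)cc(OC)c1OC`, differs from compound 2 in one place: 2,4-dichlorophenyl in place of 3-methylphenyl on an aromatic carbon. The step of a 2.2-fold lower number from compound 1 to compound 2 (0.35 log units; beyond the scatter) is the only one that bears on this change, since it too replaces the aryl group at the same position, and it was modest. Among the measured compounds shown here, no measured pair covers a chlorinated aryl group, so the direction is uncertain. A step no larger than the measured one is expected, and compound 3 is estimated to show a 1.3-fold lower number from compound 2 to compound 3 (0.10 log units; within the scatter). For compound 3 the estimate in this assay is 3000 nM, with a range from 1000 nM to 10000 nM.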

Compound 3, half-maximal inhibitory concentration: > 10000 nM
Compound 3: no number, only a limit; the forecaster's own chance of this, stated with the estimate: 5%; at least 3.3-fold (0.52 log units) between middle value and limit.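

Compound 3 is read against a limit of the assay, not a number: the limit of > 10000 nM in this assay, at which 1 of the 3 values shown sits. Even so, this position does respond to the choice of aryl group in this assay: 2,4-dichlorophenyl in place of 3-methylphenyl gave an at least 2.6-fold higher number from compound 2 to compound 3 (0.41 log units; beyond the scatter), the first step here toward a weaker inhibitor. Replacing 4-ethoxyphenyl with 2,4-dichlorophenyl gave an at least 1.1-fold higher number from compound 1 to compound 3 (0.06 log units; that floor lies within the scatter), so this comparison sets no firm order between those two groups.

Going by these compounds, it remains open whether the two chlorine atoms act together or whether a phenyl ring with one chlorine would behave differently. How an amine or a carboxylic acid on that phenyl ring would move the number is also unknown.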